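A few compounds are considered here, and "the series" means these few. Any claim that something is new, unique, unknown or untested is made for them only; others in the source may bear on it.

Measured compounds:
- compound 1, `CC1=C(C(=O)C2CC2)C(c2ccsc2)NC(=O)N1`, gives 2% in an assay on membranes from CHO cells for displacement of a labelled ligand from adenosine receptor A1 (Homo sapiens), read by scintillation counting, with a stated time of 60 min, tested at 1 uM; on this read-out lower numbers stand for less inhibition and higher numbers for more inhibition at the one concentration tested (going by the name of the read-out)
- compound 2, `CCCC(=O)C1=C(C)NC(=O)NC1c1ccsc1`, gives 6%
- compound 3, `CC1=C(C(=O)SC(C)C)C(c2ccsc2)NC(=O)N1`, gives 24%

These three share one core and differ only in the group carried on the carbonyl carbon. Compound 3 stands highest of the three numbers; its nearest neighbour is compound 2, and both gaps to the others are beyond the scatter. Compound 4, `CC1=C(C(=O)OC2CCC2)C(c2ccsc2)NC(=O)N1`, has not yet been measured. It differs from compound 3 in one place: cyclobutyloxy in place of isopropylsulfanyl on a carbonyl carbon.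

For the measured compounds named here, two measured steps bear on this carbonyl position. The step of a number 22 percentage points higher from compound 1 to compound 3 (beyond the scatter) and the step of a number 18 percentage points higher from compound 2 to compound 3 (beyond the scatter) both show that putting isopropylsulfanyl there gave a modest rise over a plain carbon group, while the step of a number 4 percentage points higher from compound 1 to compound 2 (within the scatter) between the two carbon groups stayed within the scatter. Going by the values given here, no measured step shows what a cyclobutyloxy group does here, so the expectation rests on the observation that only the isopropylsulfanyl compound rose above the others. Removing that group is therefore expected to give a modest fall, a number 10 percentage points lower from compound 3 to compound 4 (within the scatter), in this assay. Compound 4 is estimated at 14%, within a range from 2% to 32%.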

Compound 4, a percentage reported as inhibition, at one concentration (the size of the read-out at that concentration, not a potency): 40%
The estimate for compound 4 lay 26 percentage points below the measured number; measured number above the stated range.
By their numbers in this assay, from the lowest: compounds 1 and 2 (each within the scatter of the next); then compound 3; then compound 4.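

In this assay, cyclobutyloxy gives the highest number of the four at this carbonyl carbon, with a number 16 percentage points higher from compound 3 to compound 4 (beyond the scatter), a modest step, and larger steps over the two plain carbon groups: a number 34 percentage points higher from compound 2 to compound 4 (beyond the scatter) for propyl and a number 38 percentage points higher from compound 1 to compound 4 (beyond the scatter) for cyclopropyl. The rise seen earlier therefore does not belong to isopropylsulfanyl alone, since among these four compounds both groups containing sulfur or oxygen stand above both groups made only of carbon and hydrogen. Nothing available explains these rises.

Cyclobutyloxy differs from isopropylsulfanyl in both its ring and its oxygen, so these compounds cannot separate the two changes; isopropyloxy or cyclobutylsulfanyl would do so. Going by these compounds, how an amine on this carbonyl carbon would behave also remains open.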